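This account rests on a few compounds, and the source may have more. Where it says the series, first, only, none or still open, it means among the compounds named here.

Measured in a functional assay on KB cells (Homo sapiens) for cytotoxicity; a lower number here means a stronger inhibitor, a higher number a weaker inhibitor:
Compound 1 `CCCn1cc(C#N)c2c(N)ncnc21`: > 100000 nM (a limit of the assay, not a number)
Compound 2 `Cc1ccc(Cn2cc(C(=N)S)c3c(N)ncnc32)cc1`: 65000 nM
Compound 3 `Cc1cccc(Cn2cc(C(=N)S)c3c(N)ncnc32)c1`: 30000 nM

Of the two true numbers, compound 3 has the lower one, 30000 nM, so it is the stronger of that pair. Compound 2 carries 4-methylphenyl where compound 3 carries 3-methylphenyl, and that swap gives a 2.2-fold lower number from compound 2 to compound 3 (0.34 log units; beyond the scatter).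

Compound 4 `CCCn1cc(C(=N)S)c2c(N)ncnc21` is the next one to test. The change is ethyl in place of 3-methylphenyl on a saturated chain carbon bound to an aromatic nitrogen, so the ring leaves.

Going by the values given here, only one measured step bears on this. It shows that the number responds at this place, but in that step the ring stays, so it is a weak guide to losing the ring. The result for compound 1 is a limit, > 100000 nM.

With a whole ring gone, a somewhat larger move than a 2.2-fold lower number from compound 2 to compound 3 (0.34 log units; beyond the scatter) is expected, towards a higher number, meaning a weaker inhibitor. The expected change is a 2.5-fold higher number from compound 3 to compound 4 (0.40 log units; beyond the scatter). For compound 4 the estimated value is 75000 nM, with an expected range of 28000 nM to 200000 nM. The assay may well report only a limit.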

Compound 4, half-maximal inhibitory concentration: 17000 nM
Compound 4: the middle estimate sits 4.4-fold (0.64 log units) above what was measured; the whole stated range lies above it.
By their numbers in this assay, from the lowest: compounds 4 and 3 (each within the scatter of the next); then compound 2. At a limit, above all of these: compound 1.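

At this place, on a saturated chain carbon bound to an aromatic nitrogen, the aromatic ring turns out not to be needed for the effect seen in this assay: putting ethyl in place of 3-methylphenyl gives a 1.8-fold lower number from compound 3 to compound 4 (0.25 log units; within the scatter), so the two compounds stand level even though the group shrinks from seven heavy atoms to two. The same ethyl in place of 4-methylphenyl gives a 3.8-fold lower number from compound 2 to compound 4 (0.58 log units; beyond the scatter), so among the compounds with true numbers, the 4-methylphenyl group is the one that stands apart, and a smaller group at this place does no harm here. The group on the aromatic carbon also counts, with an at least 5.8-fold lower number from compound 1 to compound 4 (0.76 log units; beyond the scatter), although the starting point of that step is a limit of the assay and not a number: the limit of > 100000 nM in this assay, at which 1 of the 4 values shown sits.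

From the compounds shown here alone, it stays open how a longer chain, or a chain ending in an amine or a carboxylic acid, would behave at this place, and whether any such group would move the number beyond the scatter. Going by these compounds, it is equally open whether a group other than these two on the aromatic carbon, such as a primary amide, would give a lower number still.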